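Lactam to Cyclic Sulfonamide on a Thioether Chain

A few compounds are considered here, and "the series" means these few. Any claim that something is new, unique, unknown or untested is made for them only; others in the source may bear on it.

Compound 1 `O=C(CCCSc1nc2cc(Cl)ccc2o1)N1CCCC1`: 3.4 mL/min/g
Compound 2 `Clc1ccc2oc(SCCCN3CCCC3)nc2c1`: 1.9 mL/min/g
Compound 3 `O=C1CCCN1CCCSc1nc2cc(Cl)ccc2o1`: 4.8 mL/min/g

In an ADME assay on microsomes from liver (Homo sapiens) for metabolic stability, read by LC-MS, using NADPH, with a stated time of 45 min, tested at 0.5 uM (on this read-out higher numbers stand for fast clearance and lower numbers for slow clearance), compound 3 gives the highest number of the three. Its nearest neighbour is compound 1, with a 1.4-fold higher number from compound 1 to compound 3 (0.15 log units; within the scatter) lying within the scatter, so the two cannot be told apart. Compound 2 lies furthest away, and a 2.5-fold higher number from compound 2 to compound 3 (0.40 log units; beyond the scatter) is beyond the scatter, a modest step. The remaining pair, a 1.8-fold lower number from compound 1 to compound 2 (0.25 log units; within the scatter), is within the scatter.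

Compound 4 `O=S1(=O)CCCN1CCCSc1nc2cc(Cl)ccc2o1` has not yet been measured in this assay. It differs from compound 3 in one place: a group of 7 heavy atoms (3 carbon, 1 nitrogen, 2 oxygen, 1 sulfur; one five-membered non-aromatic ring with 2 hetero atoms) in place of a group of 6 heavy atoms (4 carbon, 1 nitrogen, 1 oxygen; one five-membered non-aromatic ring with 1 hetero atom), on a saturated chain carbon, three bonds along the chain from a sulfur

Among the measured compounds shown here, none of the measured steps changes the ring on this chain in the same way; the closest, the step from compound 2 to compound 3, introduced the carbonyl into the five-membered ring and gave a modest rise, while the step from compound 1 to compound 3 was within the scatter. For the measured compounds named here, no measured step bears directly on this exchange, so the step is expected to stay within the scatter, a 1.3-fold lower number from compound 3 to compound 4 (0.10 log units; within the scatter), with no direction favoured. Compound 4 is therefore estimated at 3.8 mL/min/g, in a range from 1.6 mL/min/g to 9 mL/min/g.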

Compound 4, intrinsic clearance in a liver preparation (reported as CLH), per the amount of preparation that the assay uses: 4.7 mL/min/g
Compound 4: middle estimate off by 1.2-fold (0.09 log units), on the low side, within the range that was stated.
By their numbers in this assay, from the lowest: compounds 2, 1, 4 and 3 (each within the scatter of the next, the first and the last beyond it).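

In this assay, setting the ring with two hetero atoms in place of 2-oxopyrrolidin-1-yl leaves compound 4 indistinguishable from compound 3 (a 1.0-fold lower number from compound 3 to compound 4 (0.01 log units; within the scatter)), so at this place on the chain the read-out does not separate the two rings, even though the entering group brings one more heavy atom, one more double bond outside aromatic rings and one more hydrogen-bond acceptor. Compound 4 also shows that the gap from the pyrrolidin-1-yl of compound 2 seen earlier is not confined to the lactam, since a second ring reproduces a modest step beyond the scatter (a 2.5-fold higher number from compound 2 to compound 4 (0.39 log units; beyond the scatter)), while the comparison with the (pyrrolidin-1-yl)carbonyl of compound 1 stays within the scatter (a 1.4-fold higher number from compound 1 to compound 4 (0.14 log units; within the scatter)), as it did for compound 3. Nothing available explains why these two rings read alike.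

The compounds shown leave open whether an open-chain amine such as dimethylamino, or a carboxylic acid, at this place on the chain would fall with compound 2 or with compound 3 and compound 4. They also leave open whether the same picture would hold on a longer chain, or with a six-membered ring such as morpholine in place of these five-membered rings.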